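This account rests on a few compounds, and the source may have more. Where it says the series, first, only, none or still open, it means among the compounds named here.

Measured so far:
- compound 1 `NC(=O)c1cccc(-c2cnc(C(=O)CCCCCCc3ccccc3)o2)c1`: 6 nM
- compound 2 `CN(C)C(=O)c1cnc(C(=O)CCCCCCc2ccccc2)o1`: 2 nM

In an assay (Rattus norvegicus) for inhibition of Fatty-acid amide hydrolase 1 (Homo sapiens) (a lower number here means a stronger inhibitor, a higher number a weaker inhibitor), compound 2 gives the lower of the two numbers; compound 1 gives the other. Within the data shown here, the only step seen is a 3.0-fold lower number from compound 1 to compound 2 (0.48 log units; beyond the scatter). Compound 3 `O=C(CCCCCCc1ccccc1)c1ncc(-c2cc(=O)[nH]c(=O)[nH]2)o1` has not yet been measured. It differs from compound 2 by a group of 8 heavy atoms (4 carbon, 2 nitrogen, 2 oxygen; one six-membered aromatic ring with 2 hetero atoms) in place of a group of 5 heavy atoms (3 carbon, 1 nitrogen, 1 oxygen; no ring), on an aromatic carbon. Among the measured compounds shown here, the new group brings back a ring, as compound 1 carries, so the single step in the other direction suggests a modest rise in the number. Compound 3 is therefore expected to give about 5 nM, within 1.5 nM to 20 nM, a step of a 2.5-fold higher number from compound 2 to compound 3 (0.40 log units; beyond the scatter).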

Compound 3, inhibition constant: 12 nM
Compound 3: middle estimate off by 2.4-fold (0.38 log units), on the low side, within the range that was stated.
By their numbers in this assay, from the lowest: compound 2; then compounds 1 and 3 (each within the scatter of the next).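

In this assay, placing a six-membered aromatic ring with 2 hetero atoms next to the ring oxygen, in place of dimethylcarbamoyl, gives a 6.0-fold higher number from compound 2 to compound 3 (0.78 log units; beyond the scatter) and so costs only a modest amount. Compared with the 3-carbamoylphenyl of compound 1, the new ring gives a 2.0-fold higher number from compound 1 to compound 3 (0.30 log units; within the scatter) and cannot be told apart from it, although the two rings differ in their atoms. No available measurement explains either step. Going by these compounds, it remains open how a carboxylic acid or an amine at this position would compare, and whether a plain phenyl ring would match these two rings.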